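Crown ether esters: a small set, one weak inhibitor

A few compounds are considered here, and "the series" means these few. Any claim that something is new, unique, unknown or untested is made for them only; others in the source may bear on it.

The set holds four esters of a macrocyclic ether alcohol, three of them measured in a functional assay on WiDr cells (Homo sapiens) for inhibition, read by sulforhodamine B assay, with a stated time of 48 h; a higher number here means a weaker inhibitor of growth, a lower number a stronger inhibitor of growth. Compound 1 `O=C(CCCCC1CCCCC1)OCC1COCCOCCOCCOCCO1` reaches only the limit of the assay, > 100000 nM. Compound 3 `O=C(CCCCC1CCCCC1)OCC1COCCOCCOCCO1` likewise returns a limit, > 100000 nM. For the measured compounds named here, compound 2 `CC(C)=CC1C(C(=O)OCC2COCCOCCOCCOCCOCCO2)C1(C)C` is the only member of the group for which this assay gives a number, 56000 nM; it is the lone value among the three because the limit of > 100000 nM in this assay, at which 2 of the 3 values shown sit, describes the other two. Compound 4 `O=C(CCCCc1ccccc1)OCC1COCCOCCOCCOCCOCCO1` is not yet measured. It is built from compound 2 by a single exchange, (4-phenylbutyl in place of 2,2-dimethyl-3-(2-methylprop-1-en-1-yl)cyclopropyl on a carbonyl carbon), namely 4-phenylbutyl in place of 2,2-dimethyl-3-(2-methylprop-1-en-1-yl)cyclopropyl on a carbonyl carbon. Going by the values given here, no measured step connects the members of this set, so the size of the change can only be guessed; the expectation is a shift toward weaker inhibition, a 1.6-fold higher number from compound 2 to compound 4 (0.21 log units; within the scatter), beyond the usual scatter. On that basis compound 4 is expected to give about 90000 nM in this assay, with a range from 40000 nM to 200000 nM, and a fair chance of returning only a limit.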

Compound 4, concentration for 50% growth inhibition: > 100000 nM
Compound 4 gave a limit, no number (the forecaster's own chance of this, stated with the estimate: 55%); middle value at least 1.1-fold (0.04 log units) away from the limit.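

In this assay, putting 4-phenylbutyl in place of 2,2-dimethyl-3-(2-methylprop-1-en-1-yl)cyclopropyl on a carbonyl carbon gives an at least 1.7-fold higher number from compound 2 to compound 4 (0.25 log units; that floor lies within the scatter). For the compounds shown here, this is the first step in the set that can be read at this position, but it is only a floor and does not establish that the exchange weakens inhibition. Compound 2 remains the only ester with a number, and compound 4 joins the others at the limit: the limit of > 100000 nM in this assay, at which 3 of the 4 values shown sit.

Going by these compounds, how far the number of compound 4 lies from that of compound 2 stays open, as does whether any other group at this position would give a number. A shorter chain, a carboxylic acid or an amine in place of 4-phenylbutyl are among the changes that the compounds shown do not address.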